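Series notes: urea analogue with 4-(trifluoromethyl)phenyl amide

A few compounds are considered here, and "the series" means these few. Any claim that something is new, unique, unknown or untested is made for them only; others in the source may bear on it.

Two compounds of the shared core carry measured values. In a functional assay on MKN-74 cells (Homo sapiens) for antiproliferative activity, with a stated time of 24 h (on this read-out higher numbers stand for weaker inhibition and lower numbers for stronger inhibition), compound 1 `NC(=O)c1c(NC(=O)c2ccc(C(F)(F)F)cc2)sc2c1CCN(Cc1ccc(Cl)cc1Cl)C2` gives 10900 nM. In this assay compound 2 `NC(=O)c1c(NC(=O)c2ccccc2F)sc2c1CCN(C(=O)Nc1ccccc1Cl)C2` gives 49600 nM, the higher of the two numbers, beyond the scatter; compound 1 and compound 2 differ in two places, so only the two values themselves are read. Compound 3 `NC(=O)c1c(NC(=O)c2ccc(C(F)(F)F)cc2)sc2c1CCN(C(=O)Nc1ccccc1Cl)C2` differs from compound 2 by 4-(trifluoromethyl)phenyl in place of 2-fluorophenyl on a carbonyl carbon. Going by the values given here, no single-change step is measured for this exchange. A lowering beyond the scatter is expected, because compound 1 bearing the 4-(trifluoromethyl)phenyl group gives 10900 nM. The expected step from compound 2 to compound 3 is a 2.5-fold lower number from compound 2 to compound 3 (0.39 log units; beyond the scatter). Compound 3 is estimated at 20000 nM, range 6000 nM to 60000 nM.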

Compound 3, half-maximal inhibitory concentration: 43900 nM
Beside the measured number, compound 3's estimate is 2.2-fold (0.34 log units) below it; low and high end bracket the measured number.
By their numbers in this assay, from the lowest: compound 1; then compounds 3 and 2 (each within the scatter of the next).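

In this assay, 4-(trifluoromethyl)phenyl in place of 2-fluorophenyl on a carbonyl carbon gives a 1.1-fold lower number from compound 2 to compound 3 (0.05 log units; within the scatter) and so stays within the scatter when the urea is present. Going by these compounds alone, on an amine nitrogen in a ring, (2-chlorophenyl)carbamoyl in place of 2,4-dichlorobenzyl gives a 4.0-fold higher number from compound 1 to compound 3 (0.61 log units; beyond the scatter) and is the only single change here beyond the scatter. No measurement on hand accounts for either step. Open, on these data alone, is how a carboxylic acid or an amine on the phenyl ring on the carbonyl carbon would read, and whether a longer chain on the ring nitrogen would keep the number of compound 1 10900 nM or move it.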